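Swapping a Sulfated Tail for an Amine on the Amide Nitrogen

The source may hold more compounds than are shown below. What is called first, only, known or untested is meant among the compounds shown, and "the series" means these compounds.

Measured so far in an assay on HEK293 cells for agonist activity at Toll-like receptor 2 (Homo sapiens); a lower number here means that less compound is needed, a higher number that more compound is needed for the effect:
compound 1 `CCCCCCCCCCCC(=O)OC[C@H](CSC[C@@H](N)C(=O)NCCOCCOS(=O)(=O)O)OC(=O)CCCCCCCCCCC`: 61 nM
compound 2 `CCCCCCCCCCCC(=O)OC[C@H](CSC[C@@H](N)C(=O)NC(C)c1ccc(O)cc1)OC(=O)CCCCCCCCCCC`: 2890 nM
compound 3 `CCCCCCCCCCCC(=O)OC[C@H](CSC[C@@H](N)C(=O)NC(C)CCC(C)C)OC(=O)CCCCCCCCCCC`: 190 nM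

Compound 1 has the lowest number of the three, needing the least compound. Changing its tail has so far only raised the number: a 3.1-fold higher number from compound 1 to compound 3 (0.49 log units; beyond the scatter), and a 47-fold higher number from compound 1 to compound 2 (1.68 log units; beyond the scatter). Compound 4 `CCCCCCCCCCCC(=O)OC[C@H](CSC[C@@H](N)C(=O)NCCN)OC(=O)CCCCCCCCCCC` carries a much smaller tail, (amino in place of 2-(sulfooxy)ethoxy on a saturated chain carbon, two bonds along the chain from an amide-type nitrogen). Neither measured step copies this change, but both show that replacing the tail costs potency, modestly for compound 3 and strongly for compound 2. Compound 4 is therefore expected to give a modestly higher number, a 2.5-fold higher number from compound 1 to compound 4 (0.39 log units; beyond the scatter), estimated at 150 nM with a likely range of 40 nM to 600 nM.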

Compound 4, half-maximal effective concentration: 5240 nM
Compound 4: middle estimate off by 35-fold (1.54 log units), on the low side, and the stated range ends below it.
By their numbers in this assay, from the lowest: compound 1; then compound 3; then compounds 2 and 4 (each within the scatter of the next).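

Amino in place of 2-(sulfooxy)ethoxy gives an 86-fold higher number from compound 1 to compound 4 (1.93 log units; beyond the scatter) and, set against the branched tail, a 28-fold higher number from compound 3 to compound 4 (1.44 log units; beyond the scatter) so this short 2-aminoethyl tail does not keep the low number that the 1,4-dimethylpentyl tail of compound 3 largely keeps. Compound 2, with its 1-(4-hydroxyphenyl)ethyl tail, and compound 4 cannot be told apart, with a 1.8-fold higher number from compound 2 to compound 4 (0.26 log units; within the scatter) lying within the usual scatter. Nothing measured here explains the loss.

Whether the sulfooxy group or the chain length lies behind the low number of compound 1 stays open. A 2-(2-aminoethoxy)ethyl or a 2-(2-hydroxyethoxy)ethyl tail on the same nitrogen would help separate the two.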